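Exchanging an acetyl for a tosyl on the sugar arm

The compounds below may be only part of what the source reports. "The series", "measured", "known", "first", "only" and "open" are said of these compounds alone.

The measured compounds in a functional assay on T47D cells (Homo sapiens) for antiproliferative activity, read by sulforhodamine B assay, with a stated time of 48 h; on this read-out lower numbers stand for stronger inhibition of growth and higher numbers for weaker inhibition of growth:
Compound 1 `CC1(C)O[C@H]2[C@H](OCc3noc(-c4ccc([N+](=O)[O-])cc4)n3)O[C@H](CO)[C@H]2O1` reaches only the assay limit, > 100000 nM.
Compound 2 `CC(=O)OC[C@H]1O[C@@H](OCc2noc(-c3ccc([N+](=O)[O-])cc3)n2)[C@@H]2OC3(CCCC3)O[C@@H]21` gives 52000 nM.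
Compound 3 `COc1cc(-c2nc(CO[C@@H]3O[C@H](CSc4ncn[nH]4)[C@H]4OC5(CCCC5)O[C@@H]34)no2)cc(OC)c1OC` gives 44000 nM.

Among the two numbers, compound 2 stands highest, yet compound 3 sits within the usual scatter of it, so the two cannot be told apart. Compound 1 gives a limit only, as stated in the limit of > 100000 nM in this assay, at which 1 of the 3 values shown sits.

Compound 4 `Cc1ccc(S(=O)(=O)OC[C@H]2O[C@@H](OCc3noc(-c4ccc([N+](=O)[O-])cc4)n3)[C@@H]3OC4(CCCC4)O[C@@H]32)cc1` differs from compound 2 in one place: (4-methylphenyl)sulfonyl in place of acetyl on an oxygen on a saturated carbon. Among the compounds with values here, no measured pair shows the effect of such a change, so the expectation for compound 4 rests on the weak growth inhibition of compound 2 alone. For compound 4 a step from compound 2 of a 1.7-fold lower number from compound 2 to compound 4 (0.24 log units; within the scatter) is expected, little beyond the scatter. Compound 4 is thus estimated at 30000 nM, between 8000 nM and 100000 nM.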

Compound 4, concentration for 50% growth inhibition: > 100000 nM
Compound 4 was reported as a limit (the forecaster's own chance of this, stated with the estimate: 25%); at least 3.3-fold (0.52 log units) between middle value and limit.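

In this assay compound 4 gives only a limit, > 100000 nM. Within the data shown here, this is the only measured pair that changes this oxygen on a saturated carbon, and (4-methylphenyl)sulfonyl in place of acetyl gives an at least 1.9-fold higher number from compound 2 to compound 4 (0.28 log units; that floor lies within the scatter), so the larger group brings no gain in growth inhibition. The true size of the step stays unknown, because the value sits at the end of the measurable range: the limit of > 100000 nM in this assay, at which 2 of the 4 values shown sit.

As far as these compounds go, whether an amine or a carboxylic acid in place of acetyl would give stronger growth inhibition than compound 2 stays open. From the compounds shown here alone, a smaller group on this oxygen, such as a methyl, remains equally open.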